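The source may hold more compounds than are shown below. What is called first, only, known or untested is meant among the compounds shown, and "the series" means these compounds.

Measured so far in an assay on membranes from brain for binding affinity to Adrenergic receptor alpha-1 (Rattus norvegicus); a lower number here means a stronger inhibitor, a higher number a weaker inhibitor:

Compound 2, `Oc1ccc2[nH]c(CN3CCC(Cc4ccccc4F)CC3)nc2c1`: 730 nM
Compound 1, `O=S(=O)(Nc1ccc2[nH]c(Cc3ccc(Oc4ccccc4)cc3)nc2c1)c1ccccc1`: 14000 nM

Compound 2 holds the lowest of the two numbers. Compound 1 gives a far higher number in this assay, and the gap between the two lies well beyond the usual scatter of repeated measurements. The two structures differ in many places at once, so no single structural change can be tied to that gap; all that can be said is that compound 2 is the stronger inhibitor of the pair.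

The step that matters here leads from compound 2 to compound 3, `Oc1ccc2[nH]c(CN3CCC(Cc4ccc(F)cc4)CC3)nc2c1`. The change is a single one: 4-fluorophenyl in place of 2-fluorophenyl on a saturated chain carbon bound to a saturated ring carbon. The fluorine simply moves from one position on the aromatic ring to another, and nothing else about the molecule changes. For the measured compounds named here, no measured pair in this set shows what such a move does in this assay, so there is no computed step to lean on. Compound 3 is expected to land close to compound 2, with a step of a 1.0-fold lower number from compound 2 to compound 3 (0.02 log units; within the scatter) that is not expected to exceed the scatter in either direction. The estimate for compound 3 in this assay is 700 nM, within a range from 250 nM to 2500 nM.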

Compound 3, half-maximal inhibitory concentration: 620 nM
Beside the measured number, compound 3's estimate is 1.1-fold (0.05 log units) above it, and the stated range covers the measured number.
By their numbers in this assay, from the lowest: compounds 3 and 2 (each within the scatter of the next); then compound 1.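

For the compounds shown here, compound 2 and compound 3 form the first pair in this set that differs in only one place, so the effect of a single change can be read for the first time: 4-fluorophenyl replaces 2-fluorophenyl on a saturated chain carbon bound to a saturated ring carbon. In this assay this change gives a 1.2-fold lower number from compound 2 to compound 3 (0.07 log units; within the scatter) and therefore does not separate the two compounds, which shows that, for this pair, moving the fluorine around the aromatic ring leaves the number within ordinary measurement noise. No supporting measurement here offers an explanation for this result.

The pair cannot show whether the fluorine itself matters, and a plain phenyl group with no fluorine would address that question, while a chlorine, a methoxy group or a nitrile in place of the fluorine would show whether other groups at this spot are treated in the same way. On these data alone, it also remains open whether the same change would give a similar result on a different core, such as that of compound 1, which differs from compound 2 in too many places to compare.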